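A few compounds are considered here, and "the series" means these few. Any claim that something is new, unique, unknown or untested is made for them only; others in the source may bear on it.

In a functional assay on the whole organism (strain Kunming) for inhibition, with Mus musculus as the target, in the writhing test, with stated times of 1 h and 15 min, at a dose of 200 mg/kg by the oral route (on this read-out lower numbers stand for less inhibition and higher numbers for more inhibition at the one dose given (going by the name of the read-out)), two compounds have been measured so far. Compound 1 `Cc1ccc(NCC2CCC/C(=C\c3ccccc3)C2=O)cc1` gives 82.8% in this assay, and compound 2 `CN(CC1CCC/C(=C\c2ccccc2)C1=O)c1ccccc1` gives 69.7%. Compound 2 therefore stands lowest of the two numbers; its nearest neighbour, compound 1, lies higher by a gap that is beyond the usual scatter of repeated measurements. The next compound, compound 3 `Cc1ccc(N(C)CC2CCC/C(=C\c3ccccc3)C2=O)cc1`, has not yet been measured. It differs from compound 2 in one place: methyl in place of hydrogen on an aromatic carbon. Among the compounds with values here, no step between two measured compounds differing in a single place has been recorded, so the size of this change is open. Because compound 1, which also bears a 4-methylphenyl group, gives 82.8%, a modest rise in this assay is expected rather than none, though the rise may stay within the scatter. Compound 3 is expected to give 76%, between 62% and 88%, an expected step of a number 6.3 percentage points higher from compound 2 to compound 3 (within the scatter).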

Compound 3, a percentage reported as inhibition, in the whole organism at one dose (the size of the read-out at that dose, not a potency): 81%
Compound 3: the middle estimate sits 5 percentage points below what was measured; the measured number falls inside the stated range.
By their numbers in this assay, from the lowest: compound 2; then compounds 3 and 1 (each within the scatter of the next).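

In this assay, within the data shown here, the change from phenyl to 4-methylphenyl gives a number 11.3 percentage points higher from compound 2 to compound 3 (beyond the scatter) and so offers the first single-change evidence that this methyl, on an aromatic carbon para to a large group, can shift the read-out. The second change, methyl in place of hydrogen on a nitrogen on an aromatic ring, gives a number 1.8 percentage points lower from compound 1 to compound 3 (within the scatter) and so shows no clear change with the 4-methylphenyl group present. The data at hand give no reason for either result.

As far as these compounds go, whether a chlorine atom, a methoxy group or a longer chain such as ethyl at this place would give a step of similar size remains open. With only one oral dose shown, it also remains open whether these steps would hold at other doses.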